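Swapping Chloro for Fluoro on a Shared Core

This account rests on a few compounds, and the source may have more. Where it says the series, first, only, none or still open, it means among the compounds named here.

Three compounds have been measured in a functional assay on the whole organism (strain Sprague-Dawley) for inhibition, with Rattus norvegicus as the target; on this read-out higher numbers stand for an effect only at larger amounts of compound and lower numbers for an effect already at smaller amounts:

compound 1 `COc1cccc2cc(C(=O)O)cnc12`: 25 mg/kg
compound 2 `O=C(O)c1cnc2c(C(F)(F)F)cccc2c1`: 50 mg/kg
compound 3 `O=C(O)c1cnc2c(Cl)cccc2c1`: 25 mg/kg

Compound 3 stands level with compound 1 at the digits shown, the two together the lowest of the three numbers, while compound 2 lies a small way off: a 2.0-fold lower number from compound 2 to compound 3 (0.30 log units; within the scatter). Compound 4 `O=C(O)c1cnc2c(F)cccc2c1` has not been measured; it differs from compound 3 by fluoro in place of chloro on an aromatic carbon. Among the measured compounds shown here, the steps that bear on this change are the earlier swaps at the same place, no change at the digits printed from compound 1 to compound 3 (within the scatter) and a 2.0-fold lower number from compound 2 to compound 3 (0.30 log units; within the scatter), each within the scatter. Three different groups there gave numbers that cannot be told apart, so no step beyond the scatter is expected in this assay; the expected step is no change at the digits printed from compound 3 to compound 4 (within the scatter). Compound 4 is therefore estimated at 25 mg/kg, in the range 12 mg/kg to 50 mg/kg.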

Compound 4, minimum effective dose: > 25 mg/kg
Compound 4: a limit, no number; the forecaster's own chance of this, stated with the estimate: 5%; the middle value sits exactly at the limit.
By their numbers in this assay, from the lowest: compounds 1, 3 and 2 (each within the scatter of the next).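

In this assay compound 4 gives > 25 mg/kg, which is a limit and not a number. Fluoro is thus the first group at this place on the shared core that is not shown to match the others: the data give a number no lower from compound 3 to compound 4 (the limit leaves the size open) and a number no lower from compound 1 to compound 4 (the limit leaves the size open), while the step between compound 2 and compound 4 cannot be read. This reading rests on a single limit: the limit of > 25 mg/kg in this assay, at which 1 of the 4 values shown sits.

From the compounds shown here alone, the true size of the fluoro step stays open. So does how an amine or a longer chain at this place would read.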